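Swapping Phenyl for Butyl on the Amide Carbonyl

The source may report more compounds than this note shows. Statements on the series, on what has been measured and on what is new or still open speak of the compounds shown alone.

Measured compounds so far:
- compound 1, `CCCC(=O)NCCC(=O)c1cc(OC)ccc1N`, "not determined" (no result reported)
- compound 2, `CCC(=O)NCCC(=O)c1cc(OC)ccc1N`, 99.4%
- compound 3, `COc1ccc(N)c(C(=O)CCNC(=O)c2ccccc2)c1`, 97.2%

All three share one core, and differ only in the group attached to the amide carbonyl carbon. In a functional assay for inhibition of kynurenine 3-monooxygenase (Rattus norvegicus), tested at 1 mM (a higher number here means more inhibition at the concentration tested (going by the name of the read-out), a lower number less inhibition), compound 2 gives 99.4%, and in this assay compound 3 gives 97.2%. Compound 3 thus holds the lower of the two numbers, but the step of a number 2.2 percentage points lower from compound 2 to compound 3 (within the scatter) is within the scatter, so the two cannot be told apart on these data. In this assay compound 1 gives "not determined" (no result reported).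

Compound 4 is `CCCCC(=O)NCCC(=O)c1cc(OC)ccc1N`. Its difference from compound 3 is butyl in place of phenyl on a carbonyl carbon. Among the compounds with values here, only one measured step bears on this place: a number 2.2 percentage points lower from compound 2 to compound 3 (within the scatter), where phenyl replaced ethyl on the same carbonyl carbon and the number hardly moved. Compound 2 already carries a chain on that carbon and sits high, and compound 3 with its phenyl sits almost as high. A longer chain in place of the phenyl is therefore expected to leave the inhibition about where it is, with the step of a number 0.2 percentage points lower from compound 3 to compound 4 (within the scatter) expected to stay within the scatter. For compound 4 the estimate is 97%, expected to fall between 85% and 100%.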

Compound 4, a percentage reported as inhibition, at one concentration (the size of the read-out at that concentration, not a potency): 97.2%
Compound 4: the middle estimate sits 0.2 percentage points below what was measured; low and high end bracket the measured number.
By their numbers in this assay, from the lowest: compounds 3, 4 and 2 (each within the scatter of the next).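

In this assay, the direct swap of phenyl for butyl on the amide carbonyl carbon gives no change at the digits printed from compound 3 to compound 4 (within the scatter), which shows that a ring at this place can give way to an open chain with no detectable effect on the read-out. The comparison of the two chains gives a number 2.2 percentage points lower from compound 2 to compound 4 (within the scatter), so adding length to the chain also produces no difference that can be told from scatter, and ethyl, butyl and phenyl cannot be separated at this position. Nothing available here explains why these three groups look alike in this test.

The compounds shown stay within plain carbon groups, so it remains open whether a chain much longer than butyl, a branched chain such as tert-butyl, or a chain ending in an amine or a carboxylic acid would hold the number equally well. The read-out is also taken at one concentration and is not a potency, which leaves open whether compound 2, compound 3 and compound 4 would still look alike at lower concentrations.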